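This account rests on a few compounds, and the source may have more. Where it says the series, first, only, none or still open, it means among the compounds named here.

Compound 1 `CCCOC(=O)C1=C(C)NC(=O)NC1c1ccco1` in an assay on membranes from HeLa cells for displacement of a labelled ligand from adenosine receptor A3 (Homo sapiens), read by scintillation counting, with a stated time of 180 min, tested at 1 uM (a lower number here means less inhibition, a higher number more inhibition at the concentration tested (going by the name of the read-out)), gives 3%. Compound 2 `CC1=C(C(=O)OCc2ccccc2)C(c2ccco2)NC(=O)N1` gives 3%, so no change at the digits printed from compound 1 to compound 2 (within the scatter). Compound 3 `CCCOC(=O)C1=C(C)NC(=O)NC1c1cccs1` gives 32%, and a number 29 percentage points higher from compound 1 to compound 3 (beyond the scatter). Compound 1 thus stands level with compound 2, the two together at the bottom of the three numbers, with compound 3 the only one apart.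

Compound 4 `CC1=C(C(=O)C2CC2)C(c2ccco2)NC(=O)N1` differs from compound 1 in one place: cyclopropyl in place of propoxy on a carbonyl carbon. For the measured compounds named here, no measured step alters the carbonyl carbon itself; the nearest is the change on the oxygen of the ester, which gave no change at the digits printed from compound 1 to compound 2 (within the scatter). On that weak ground a change in this assay from compound 1 to compound 4 of only small size, if any, is expected, giving a number 5 percentage points higher from compound 1 to compound 4 (within the scatter). Compound 4 is therefore estimated at 8%, within 0% to 30%.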

Compound 4, a percentage reported as inhibition, at one concentration (the size of the read-out at that concentration, not a potency): 7%
Estimate against measurement, compound 4: 1 percentage points above; low and high end bracket the measured number.
By their numbers in this assay, from the lowest: compounds 1, 2 and 4 (each within the scatter of the next); then compound 3.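

In this assay, cyclopropyl in place of propoxy on the carbonyl carbon gives a number 4 percentage points higher from compound 1 to compound 4 (within the scatter), so with furan-2-yl kept, this first change to the group bound directly to that carbonyl carbon stays within the scatter, as the earlier change further out on the ester did. The ester oxygen can therefore go without a step beyond the scatter, and only the thiophen-2-yl change remains beyond it. No measurement on hand gives a reason for this result.

As far as these compounds go, whether an amine or a longer chain on this carbonyl carbon would give a step beyond the scatter remains open. So does the size of the thiophen-2-yl step when cyclopropylcarbonyl replaces propoxycarbonyl.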